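Benzylamino for 2-methoxyethoxy: cytotoxicity working notes

A few compounds are considered here, and "the series" means these few. Any claim that something is new, unique, unknown or untested is made for them only; others in the source may bear on it.

Compound 1 (`COCCOc1nc(N)nc2c1ncn2/C=C1/CC1(CO)CO`) is the starting point in an ADME assay on Akata cells (Homo sapiens) for cytotoxicity, with a stated time of 7 days; a lower number here means that less compound is tolerated, a higher number that more compound is tolerated. Compound 1 gives > 20000 nM, which is a limit and not a number. Compound 2 (`CN(C)c1nc(N)nc2c1ncn2/C=C1/CC1(CO)CO`) gives > 24000 nM, which is also a limit. No numerical value is therefore available for either compound, and compound 1 cannot be ranked on this read-out.

The next change leads to compound 3 (`Nc1nc(NCc2ccccc2)c2ncn(/C=C3/CC3(CO)CO)c2n1`), with benzylamino in place of 2-methoxyethoxy on an aromatic carbon. For the measured compounds named here, the entering group brings one six-membered aromatic ring of carbon only, and no compound measured so far carries it.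

Going by the values given here, the only measured step bearing on this change is a step that the two limits leave unreadable from compound 1 to compound 2. It also replaces 2-methoxyethoxy at the same place, but it supplies no size to carry over. No step beyond the scatter is therefore expected in this assay, and no direction can be drawn. The estimated step is a number no higher from compound 1 to compound 3 (the limit leaves the size open). For compound 3 the expected half-maximal cytotoxic concentration is 20000 nM, with an estimated range of 6000 nM to 50000 nM.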

Compound 3, half-maximal cytotoxic concentration: > 24000 nM
Compound 3 gave a limit, no number; the forecaster's own chance of this, stated with the estimate: 60%; middle value at least 1.2-fold (0.07 log units) away from the limit.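

In this assay, for the compounds shown here, compound 1, compound 2 and compound 3 all give limits and not numbers, and no step from compound 1 to compound 3 or from compound 2 to compound 3 can be read. The compounds shown leave open whether 2-methoxyethoxy, dimethylamino and benzylamino differ at all on this read-out.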